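The source may report more compounds than this note shows. Statements on the series, on what has been measured and on what is new or still open speak of the compounds shown alone.

Measured compounds in an assay on HEK293 cells for displacement of a labelled ligand from NPC1-like intracellular cholesterol transporter 1 (Homo sapiens); on this read-out lower numbers stand for stronger inhibition and higher numbers for weaker inhibition:
- Compound 1 `CCOC(=O)C1CCN(C(=O)CN2CN(c3ccccc3)C3(CCN(C(=O)c4ccc(C5CCCCC5)cc4)CC3)C2=O)CC1` gives 900 nM
- Compound 2 `CC(C)(C)OC(=O)NCCNC(=O)CN1CN(c2ccccc2)C2(CCN(C(=O)c3ccc(C(C)(C)C)cc3)CC2)C1=O` gives 10900 nM
- Compound 3 `CCC1CCCN(C(=O)CN2CN(c3ccccc3)C3(CCN(C(=O)c4ccc(C(C)(C)C)cc4)CC3)C2=O)C1` gives 3900 nM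

Compound 1 has the lowest number of the three, so it displaces the labelled ligand most strongly; the nearest of the others is compound 3 and the furthest compound 2, both beyond the scatter.

Compound 4 `CS(=O)(=O)NCCCNC(=O)CN1CN(c2ccccc2)C2(CCN(C(=O)c3ccc(C4CCCCC4)cc3)CC2)C1=O` is compound 1 with one change: (3-(methanesulfonamido)propyl)amino in place of 4-(ethoxycarbonyl)piperidin-1-yl on a carbonyl carbon

Among the measured compounds shown here, only one measured step touches this carbonyl carbon, namely a 2.8-fold lower number from compound 2 to compound 3 (0.45 log units; beyond the scatter), where an open chain bearing a carbamate gave way to a ring and the number dropped. The change from compound 1 to compound 4 runs the opposite way, a ring leaving and an open chain with a sulfonamide entering, so a rise of roughly that size is expected in this assay. For the measured compounds named here, the two reference compounds carry a tert-butyl where compound 1 carries a cyclohexyl, and no step between those groups has been measured, which widens the uncertainty. For compound 4 the expected step is a 3.3-fold higher number from compound 1 to compound 4 (0.52 log units; beyond the scatter), giving an estimate of 3000 nM with a likely range of 1000 nM to 10000 nM.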

Compound 4, half-maximal inhibitory concentration: 3800 nM
For compound 4 the middle estimate is 1.3-fold (0.10 log units) below the measured one; measured number inside the range.
By their numbers in this assay, from the lowest: compound 1; then compounds 4 and 3 (each within the scatter of the next); then compound 2.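

In this assay, swapping 4-(ethoxycarbonyl)piperidin-1-yl for (3-(methanesulfonamido)propyl)amino on this carbonyl carbon gives a 4.2-fold higher number from compound 1 to compound 4 (0.63 log units; beyond the scatter) in a compound carrying a cyclohexyl group. Among the compounds shown here, the only earlier step at this carbon joined two compounds carrying a tert-butyl group, so the ring now goes with the lower number in a second pair, with a cyclohexyl in place of the tert-butyl and a sulfonamide in the chain in place of a carbamate. No measurement shown gives a reason for this rise.

The ring, the ester and the sulfonamide all change together, so the compounds shown leave open which of them governs the number. A plain piperidin-1-yl without the ester, or a propyl chain ending in a carboxylic acid or an amine, would help to separate these parts.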